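Chain homologation in a pentafluoroalkyl acid series

The source may hold more compounds than are shown below. What is called first, only, known or untested is meant among the compounds shown, and "the series" means these compounds.

Measured so far:
Compound 1 `C[C@]1(c2ccc(O)cc2)CSc2cc(O)ccc2[C@H]1CCCCCCCCC(CCCCC(F)(F)C(F)(F)F)C(=O)O`: 87%
Compound 2 `C[C@]1(c2ccc(O)cc2)CSc2cc(O)ccc2[C@H]1CCCCCCCCC(CCCCCC(F)(F)C(F)(F)F)C(=O)O`: 86%
Compound 3 `C[C@]1(c2ccc(O)cc2)CSc2cc(O)ccc2[C@H]1CCCCCCCCCC(CCCC(F)(F)C(F)(F)F)C(=O)O`: 81%

All three were run in a functional assay on the whole organism for antagonist activity, with Mus musculus as the target, at a dose of 10 mg/kg by the oral route; a lower number here means a weaker effect, a higher number a stronger effect of the compound at the dose given. Compound 1 gives 87%, compound 2 gives 86% and compound 3 gives 81%; the gaps from compound 3 to compound 1 and to compound 2 lie within the scatter, so no order among the three can be read. For the measured compounds named here, the one counted change, (2,2,3,3,3-pentafluoropropyl in place of 1,1,2,2,2-pentafluoroethyl on a saturated chain carbon, five bonds along the chain from a carbonyl carbon), gave a number 1 percentage points lower from compound 1 to compound 2 (within the scatter). Compound 3 and compound 1 are built from the same atoms joined differently; the difference between the two cores is not broken down here.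

Compound 4 `C[C@]1(c2ccc(O)cc2)CSc2cc(O)ccc2[C@H]1CCCCCCCCCC(CCCCC(F)(F)C(F)(F)F)C(=O)O` is not yet measured. It differs from compound 3 by 2,2,3,3,3-pentafluoropropyl in place of 1,1,2,2,2-pentafluoroethyl on a saturated chain carbon, four bonds along the chain from a carbonyl carbon. This is the same kind of change as from compound 1 to compound 2, but the place differs: four bonds along the chain from a carbonyl carbon rather than five. Because the earlier step was a number 1 percentage points lower from compound 1 to compound 2 (within the scatter), the expected step in this assay is a number 1 percentage points lower from compound 3 to compound 4 (within the scatter), essentially flat. Compound 4 is accordingly estimated at 80%, expected to fall between 70% and 90%. Going by the values given here, that expectation rests on compound 3 at 81% and on the single earlier step alone.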

Compound 4, a percentage reported as inhibition, in the whole organism at one dose (the size of the read-out at that dose, not a potency): 79%
Estimate against measurement, compound 4: 1 percentage points above; the measured number falls inside the stated range.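

In this assay, 2,2,3,3,3-pentafluoropropyl in place of 1,1,2,2,2-pentafluoroethyl on a saturated chain carbon, four bonds along the chain from a carbonyl carbon, gave a number 2 percentage points lower from compound 3 to compound 4 (within the scatter). Set beside the earlier step, the change carries from one core to the other with no difference that can be read: the same change on two cores in this assay, a number 1 percentage points lower (within the scatter) from compound 1 to compound 2 and a number 2 percentage points lower (within the scatter) from compound 3 to compound 4, 1 percentage points apart, within the scatter of two such steps. This holds for these two cores and this single oral dose only; the read-out gives the size of the effect at that dose, and nothing follows for other doses or other cores.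

The compounds shown leave open how 3,3,4,4,4-pentafluorobutyl, a chain ending in trifluoromethyl or an unfluorinated alkyl chain would read in this assay. They also leave open whether the same step holds when a primary amide stands in place of the carboxylic acid.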